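A few compounds are considered here, and "the series" means these few. Any claim that something is new, unique, unknown or untested is made for them only; others in the source may bear on it.

Measured so far in a functional assay on HeLa cells (Homo sapiens) for antiproliferative activity, read by MTT assay, with a stated time of 48 h; on this read-out higher numbers stand for weaker inhibition and lower numbers for stronger inhibition:
compound 1 `N#Cc1nc2c(-c3nc4ccccc4[nH]3)c(N)n(CCO)c2nc1C#N`; compound 1 reaches only the limit of > 50000 nM
compound 2 `CCCCn1c(N)c(-c2nc3ccccc3[nH]2)c2nc(C#N)c(C#N)nc21`; compound 2 also reaches only the limit of > 50000 nM
compound 3 `N#Cc1nc2c(-c3nc4ccccc4[nH]3)c(N)n(CCCN3CCCCC3)c2nc1C#N`; compound 3 gives 6680 nM

Within the data shown here, compound 3 stands alone as the only finite number among the three; the other two values are limits of this assay (the limit of > 50000 nM in this assay, at which 2 of the 3 values shown sit). The steps reaching it are an at least 7.4-fold lower number from compound 1 to compound 3 (0.87 log units; beyond the scatter) and an at least 7.4-fold lower number from compound 2 to compound 3 (0.87 log units; beyond the scatter); the step that the two limits leave unreadable from compound 1 to compound 2 cannot be read from two limits.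

Compound 4 `N#Cc1nc2c(-c3nc4ccccc4[nH]3)c(N)n(CCCNc3ccccc3)c2nc1C#N` differs from compound 3 by anilino in place of piperidin-1-yl on a saturated chain carbon, three bonds along the chain from an aromatic nitrogen. Among the measured compounds shown here, no measured pair shows this exact exchange. The closest bearing is the step from compound 2, whose butyl chain carries no amine, to compound 3 with its piperidin-1-yl, which was at least modest; compound 4 likewise loses the piperidin-1-yl, though it gains an anilino rather than a bare methyl, so the comparison is indirect. The expectation is therefore a weakening, of a size estimated as a 3.3-fold higher number from compound 3 to compound 4 (0.52 log units; beyond the scatter) in this assay, with a real chance that only a limit is returned. Compound 4 is thus expected to give about 22000 nM, within a range of 6000 nM to 60000 nM.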

Compound 4, half-maximal inhibitory concentration: 26300 nM
The estimate for compound 4 lay 1.2-fold (0.08 log units) below the measured number; the measured number falls inside the stated range.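

In this assay, among these compounds, compound 4 gives the first finite reading for an exchange of the group on this propyl chain: anilino in place of piperidin-1-yl produces a 3.9-fold higher number from compound 3 to compound 4 (0.60 log units; beyond the scatter), so a nitrogen on the chain does not by itself hold the level of compound 3. The comparisons with the compounds lacking that nitrogen, an at least 1.9-fold lower number from compound 2 to compound 4 (0.27 log units; that floor lies within the scatter) and an at least 1.9-fold lower number from compound 1 to compound 4 (0.27 log units; that floor lies within the scatter), are only floors that lie within the scatter, so compound 4 cannot be ranked against either. Compound 1 and compound 2 remain limits and not numbers, and the step between them cannot be read: the limit of > 50000 nM in this assay, at which 2 of the 4 values shown sit.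

The compounds shown leave open whether the difference follows the saturated ring of piperidin-1-yl, the aromatic ring of anilino, or the hydrogen on the anilino nitrogen. A methyl(phenyl)amino group, a morpholin-4-yl group or an open-chain diethylamino group on the same propyl chain would bear on that question, and a butyl or ethyl linker carrying piperidin-1-yl would show how much the chain length itself counts.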